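The source may hold more compounds than are shown below. What is called first, only, known or untested is meant among the compounds shown, and "the series" means these compounds.

Compound 3 `CSc1ccc(CNc2nc(SC)nc3ccccc23)cc1` was tested in a functional assay on CCRF-CEM cells (Homo sapiens) for cytotoxicity, read by MTT assay, with a stated time of 72 h; on this read-out lower numbers stand for stronger inhibition of growth and higher numbers for weaker inhibition of growth. In this assay compound 3 gives > 100000 nM, which is a limit of the assay rather than a number. Compound 1 `COc1ccc(CNc2nc([Se]C)nc3ccccc23)cc1` gives > 100000 nM, also a limit. Compound 2 `CCCCC[Se]c1nc(NCc2ccc(SC)cc2)c2ccccc2n1` gives 35000 nM. For the measured compounds named here, the only measured step, an at least 2.8-fold higher number from compound 2 to compound 3 (0.45 log units; beyond the scatter), changes a different group from the one considered here, so it offers no direct guide. Compound 4 `CSc1ccc(CNc2nc([Se]C)nc3ccccc23)cc1` differs from compound 3 by a group of 2 heavy atoms (1 carbon, 1 selenium; no ring) in place of a group of 2 heavy atoms (1 carbon, 1 sulfur; no ring), on an aromatic carbon. Going by the values given here, no measured step swaps these two groups at this place, and compounds 1 and 3 both sit at the limit of > 100000 nM in this assay, at which 2 of the 3 values shown sit. The expected step that the limit leaves unreadable from compound 3 to compound 4 is therefore none beyond the scatter. Compound 4 is estimated at 150000 nM, between 60000 nM and 400000 nM, most likely reported again only as a limit.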

Compound 4, concentration for 50% growth inhibition: 48700 nM
Beside the measured number, compound 4's estimate is 3.1-fold (0.49 log units) above it; the measured number lies below the stated range.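

In this assay, the position between two ring nitrogen atoms responds to the atom swap alone, with selenium in place of sulfur: an at least 2.0-fold lower number from compound 3 to compound 4 (0.31 log units; beyond the scatter). The other end of the molecule also counts once selenium is present, with methylsulfanyl in place of methoxy: an at least 2.0-fold lower number from compound 1 to compound 4 (0.31 log units; beyond the scatter). The chain on selenium shows no clear effect, since its step lies within the scatter: a 1.4-fold higher number from compound 2 to compound 4 (0.14 log units; within the scatter).

As far as these compounds go, compound 1 and compound 3 carry limits, and the full size of their steps stays open. Also open, from the compounds shown here alone, is how an amine at this position would compare with the sulfur and selenium groups.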